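The source may hold more compounds than are shown below. What is called first, only, known or untested is meant among the compounds shown, and "the series" means these compounds.

Of the compounds shown here, two have been tested in an assay on isolated protein for inhibition of DNA topoisomerase 1 (Homo sapiens), with a stated time of 30 min, tested at 100 uM; a lower number here means less inhibition, a higher number more inhibition at the concentration tested (going by the name of the read-out). Compound 1 `Cc1ccsc1-c1cc(-c2ccoc2)cc(-c2ccco2)n1` gives 5.4% in this assay, and compound 2 `Cc1ccc(-c2cc(-c3ccoc3)cc(-c3ccc(Cl)s3)n2)o1` gives 13.2%. Compound 2 carries the higher of the two numbers, but the gap to compound 1 lies within the scatter of repeated measurements, so the two values cannot be told apart, and both read as weak inhibition at the concentration used.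

Compound 3 `Clc1ccc(-c2cc(-c3ccoc3)cc(-c3ccc(Cl)s3)n2)cc1` is the next compound to be measured in this assay. It differs from compound 2 in one place: 4-chlorophenyl in place of 5-methylfuran-2-yl on an aromatic carbon. For the measured compounds named here, no step between measured compounds stands behind this change, so nothing measured supports a direction for it.

Given that both measured compounds sit at low inhibition, the step from compound 2 to compound 3 is expected to be small, likely none beyond the scatter, with a number 1.2 percentage points lower from compound 2 to compound 3 (within the scatter). Compound 3 is expected to give 12% in this assay, with a range from 0% to 30%, because compound 2 gives 13.2% and compound 1 gives 5.4%.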

Compound 3, a percentage reported as inhibition, at one concentration (the size of the read-out at that concentration, not a potency): 2.3%
Beside the measured number, compound 3's estimate is 9.7 percentage points above it; the range from low to high includes it.
By their numbers in this assay, from the lowest: compounds 3, 1 and 2 (each within the scatter of the next, the first and the last beyond it).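

In this assay, for the compounds shown here, the first step at this position is 4-chlorophenyl in place of 5-methylfuran-2-yl on the aromatic carbon next to the ring nitrogen, giving a number 10.9 percentage points lower from compound 2 to compound 3 (beyond the scatter). With the 5-chlorothiophen-2-yl and furan-3-yl groups held constant, the read-out therefore responds to the group at this position, although compound 3 still gives only 2.3% at the concentration tested. Nothing measured bears on the reason for this fall.

This single step exchanges a five-membered aromatic ring with 1 hetero atom for a six-membered aromatic ring of carbon only, and it also adds a chlorine, so the contribution of each remains unresolved. Also open, on these data alone, are how an aminomethyl group or a carboxylic acid would read at this position and whether the same step would recur with another group in place of 5-chlorothiophen-2-yl.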